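The compounds below may be only part of what the source reports. "The series", "measured", "known", "first", "only" and "open" are said of these compounds alone.

Within the data shown here, compound 1 `Cc1cccc(-c2noc([C@@H](C)NC(=O)c3cc(C4CC4)nn3C)n2)c1` is the one compound here with a full number: in an assay on T-REx-293 cells for inhibition of potassium channel subfamily T member 1 (Homo sapiens), read by patch clamp (a higher number here means a weaker inhibitor, a lower number a stronger inhibitor), compound 1 gives 3310 nM. Compound 2 `C[C@H](NC(=O)c1cc(C(F)(F)F)nn1C)c1nc(-c2ccccn2)no1` is measured in this assay too, but in this assay compound 2 gives > 30000 nM, which is a limit of the assay and not a number. Compound 2 stands at the limit of > 30000 nM in this assay, at which 1 of the 2 values shown sits, so only a bound is known for it. Compound 3 `CNc1cc(-c2noc([C@H](C)NC(=O)c3cc(C(F)(F)F)nn3C)n2)ccn1` differs from compound 2 in one place: 2-(methylamino)pyridin-4-yl in place of pyridin-2-yl on an aromatic carbon. No measured step between two compounds that differ only in this way is available, so the size of the change in this assay cannot be read from the numbers shown. A step of an at least 2.5-fold lower number from compound 2 to compound 3 (0.39 log units; beyond the scatter) toward stronger inhibition is expected, but with little confidence. My estimate for compound 3 in this assay is 12000 nM, expected to fall between 3000 nM and 30000 nM.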

Compound 3, half-maximal inhibitory concentration: 195 nM
For compound 3 the middle estimate is 62-fold (1.79 log units) above the measured one; measured number outside the range, below it.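

Among these compounds, until now no measured step showed how much the group on this aromatic carbon, between two ring nitrogen atoms, matters. In this assay, replacing pyridin-2-yl with 2-(methylamino)pyridin-4-yl gives an at least 150-fold lower number from compound 2 to compound 3 (2.18 log units; beyond the scatter), so for this pair the choice of group at this place has a large effect on inhibition. Compound 2 sits at a limit of the assay, so this step is a minimum and not an exact size: the limit of > 30000 nM in this assay, at which 1 of the 3 values shown sits.

The change alters two things at once, the point at which the pyridine ring is joined and the added methylamino group, and this pair cannot separate them. From the compounds shown here alone, whether plain pyridin-4-yl, or a 2-aminopyridin-4-yl or 2-(dimethylamino)pyridin-4-yl group, would give a similar step remains open.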